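The compounds below may be only part of what the source reports. "The series", "measured", "known", "first", "only" and "open" are said of these compounds alone.

Compound 1 `O=C(NN1CCOCC1)c1c(O)c2cccnc2n(-c2ccccc2)c1=O` stands at the bottom of the three measured numbers: in a functional assay on the whole organism for inhibition, with Rattus norvegicus as the target, read by paw edema, at a dose of 100 mg/kg by the oral route (on this read-out lower numbers stand for less inhibition and higher numbers for more inhibition at the one dose given (going by the name of the read-out)), compound 1 gives -8.5%. Compound 2 `O=C(Nc1cccc([N+](=O)[O-])c1)c1c(O)c2cccnc2n(-c2ccccc2)c1=O` gives 5.7% and compound 3 `COc1ccccc1NC(=O)c1c(O)c2cccnc2n(-c2ccccc2)c1=O` gives 8.1% in this assay, so both aromatic amide substituents sit above the morpholin-4-yl compound, with a number 14.2 percentage points higher from compound 1 to compound 2 (beyond the scatter) and a number 16.6 percentage points higher from compound 1 to compound 3 (beyond the scatter).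

Compound 4 `O=C(Nc1cccnc1)c1c(O)c2cccnc2n(-c2ccccc2)c1=O` differs from compound 1 by pyridin-3-yl in place of morpholin-4-yl on an amide-type nitrogen. The two measured steps that start from compound 1 both exchange morpholin-4-yl for a six-membered aromatic ring and both give a modest rise beyond the scatter, so a rise of similar size is expected here, namely a number 14.5 percentage points higher from compound 1 to compound 4 (beyond the scatter). Compound 4 is therefore estimated to give 6% in this assay, with a likely range from -6% to 18%.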

Compound 4, a percentage reported as inhibition, in the whole organism at one dose (the size of the read-out at that dose, not a potency): 30.3%
Beside the measured number, compound 4's estimate is 24.3 percentage points below it, outside the stated range (above it).
By their numbers in this assay, from the lowest: compound 1; then compounds 2 and 3 (each within the scatter of the next); then compound 4.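

At this amide-type nitrogen, the kind of aromatic ring matters, not merely its presence: in this assay the change to pyridin-3-yl gives a number 38.8 percentage points higher from compound 1 to compound 4 (beyond the scatter), and it also stands clear of the other two aromatic groups, with a number 22.2 percentage points higher from compound 3 to compound 4 (beyond the scatter) and a number 24.6 percentage points higher from compound 2 to compound 4 (beyond the scatter). Of these aromatic groups, only pyridin-3-yl has a hetero atom in its ring, but one compound cannot separate that feature from the loss of the methoxy or nitro group. Nothing measured here explains the rise. Still open, as far as these compounds go, is how plain phenyl, pyridin-2-yl or pyridin-4-yl would compare on the same nitrogen.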